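The source may hold more compounds than are shown below. What is called first, only, known or untested is meant among the compounds shown, and "the series" means these compounds.

In an assay on isolated protein for inhibition of ribosomal protein S6 kinase alpha-1 (Homo sapiens), read by mobility shift assay, tested at 30 uM (on this read-out higher numbers stand for more inhibition at the one concentration tested (going by the name of the read-out) and lower numbers for less inhibition), compound 3 `Cc1cc2c(c(N)nn2C)c(=O)[nH]1` gives 2%, the lowest of the three numbers measured. Compound 1 `Cc1cc2[nH]nc(N)c2c(=O)[nH]1` gives 6%, and the step of a number 4 percentage points lower from compound 1 to compound 3 (within the scatter) lies within the scatter. Compound 2 `CN1CCN(c2ccc(-c3cc4[nH]nc(N)c4c(=O)[nH]3)cc2)CC1` gives 26%, which stands beyond the scatter above compound 3. Compound 4 `Cn1nc(N)c2c(=O)[nH]c(-c3ccccn3)cc21` differs from compound 3 by pyridin-2-yl in place of methyl on an aromatic carbon. Going by the values given here, no measured step covers this change; the only measured step, from compound 1 to compound 3, concerns a methyl on an aromatic nitrogen and was within the scatter. Among the compounds with values here, compound 2, the one compound bearing an aromatic ring rather than a methyl on the shared core, shows a higher number than compound 1, though no single step between them has been derived. A modest rise is therefore expected for compound 4, a number 10 percentage points higher from compound 3 to compound 4 (within the scatter). Compound 4 is estimated at 12%, between 0% and 30%.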

Compound 4, a percentage reported as inhibition, at one concentration (the size of the read-out at that concentration, not a potency): 9%
For compound 4 the middle estimate is 3 percentage points above the measured one, and the stated range covers the measured number.
By their numbers in this assay, from the lowest: compounds 3, 1 and 4 (each within the scatter of the next); then compound 2.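

In this assay pyridin-2-yl in place of methyl on this aromatic carbon gives a number 7 percentage points higher from compound 3 to compound 4 (within the scatter), so this larger aromatic group leaves the number within the scatter of the methyl compound. The earlier compounds shown here offered no step at this carbon, only one on the aromatic nitrogen. No evidence is available to explain the size of this step. As far as these compounds go, whether an amine or a carboxylic acid on this aromatic carbon would move the number beyond the scatter stays open. Also open, from the compounds shown here alone, is whether pyridin-2-yl gives a similar number with hydrogen in place of methyl on the aromatic nitrogen.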